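Diaryl piperidine propoxy series: replacing the acetylphenyl cap

A few compounds are considered here, and "the series" means these few. Any claim that something is new, unique, unknown or untested is made for them only; others in the source may bear on it.

Measured so far:
compound 1, `COc1cc(C(C)=O)ccc1OCCCN1CCC(C(c2ccc(F)c(F)c2)c2ccc(F)c(F)c2)CC1`, 2.51 nM
compound 2, `COc1cc(C(C)=O)ccc1OCCCN1CCC(C(C(N)=O)(c2ccc(F)cc2)c2ccc(F)cc2)CC1`, 25.1 nM
compound 3, `CC(=O)c1ccc(OCCCN2CCC(C(c3ccc(F)cc3)c3ccc(F)cc3)CC2)cc1`, 2.51 nM

In a functional assay (aorta) with Oryctolagus cuniculus as the target (a lower number here means tighter binding, a higher number weaker binding), compound 3 stands level with compound 1 at the digits given, the two together holding the lowest numbers of the three; the gap between them is within the scatter. Compound 2 sits furthest away, with a higher number than compound 3, a difference beyond the scatter.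

Compound 4, `Fc1ccc(C(c2ccc(F)cc2)C2CCN(CCCOc3cccc4ccccc34)CC2)cc1`, is not yet measured. It is set against compound 3 by naphthalen-1-yl in place of 4-acetylphenyl on an oxygen on a saturated carbon: the group that leaves carries one hydrogen-bond acceptor, the group that enters carries none, and the second aromatic ring enters at the same oxygen on the saturated carbon. Within the data shown here, no measured pair in this set shows this change, so its direction is not known from the data.

Compound 4 is expected to sit near compound 3, with the step of a 1.6-fold higher number from compound 3 to compound 4 (0.20 log units; within the scatter) estimated as small and toward a higher number, probably within or only just beyond the scatter. For compound 4 the estimate in this assay is 4 nM, with a range of 1.3 nM to 13 nM.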

Compound 4, dissociation constant: 5.01 nM
Compound 4: middle estimate off by 1.3-fold (0.10 log units), on the low side, and the stated range covers the measured number.
By their numbers in this assay, from the lowest: compounds 1, 3 and 4 (each within the scatter of the next); then compound 2.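

In this assay the first pair differing in one place gives a step (a 2.0-fold higher number from compound 3 to compound 4 (0.30 log units; within the scatter)) that stays within the scatter. On an oxygen on a saturated carbon, 4-acetylphenyl can therefore give way to naphthalen-1-yl, losing the hydrogen-bond acceptor and adding a second aromatic ring, without a change that the measurement can separate from repeat variation. This single pair shows tolerance for this one swap on this core, and no measurement offered here accounts for it.

Still open, from the compounds shown here alone, is whether the same swap stays this quiet on the cores of compound 1 and compound 2. Also open, going by these compounds, is how a carboxylic acid or an amine would read at this position in place of 4-acetylphenyl.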